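The compounds below may be only part of what the source reports. "The series", "measured", "known", "first", "only" and "open" are said of these compounds alone.

Compound 3 `COc1nc2ccc(Br)cc2cc1C(c1ccccc1)n1cc(CCO)nn1` is the middle point of three compounds that share one core and differ only in the group on the 1,2,3-triazolyl ring. In an ADME assay on SK-OV-3 cells (Homo sapiens) for cytotoxicity, read by sulforhodamine B assay, with a stated time of 48 h, tested at 10 uM (a lower number here means less inhibition, a higher number more inhibition at the concentration tested (going by the name of the read-out)), compound 3 gives 8.46%, the second highest of the three numbers shown. Its nearest neighbour is compound 2 `CCCCCc1cn(C(c2ccccc2)c2cc3cc(Br)ccc3nc2OC)nn1`, which in this assay gives 10.5%; the step of a number 2 percentage points lower from compound 2 to compound 3 (within the scatter) is within the scatter. The furthest is compound 1 `CCOC(=O)c1cn(C(c2ccccc2)c2cc3cc(Br)ccc3nc2OC)nn1`, which in this assay gives 2.01%; the step of a number 6.5 percentage points higher from compound 1 to compound 3 (within the scatter) is likewise within the scatter, as is the step of a number 8.5 percentage points higher from compound 1 to compound 2 (within the scatter).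

Compound 4 `COc1nc2ccc(Br)cc2cc1C(c1ccccc1)n1cc(CO)nn1` differs from compound 3 by a single change: hydroxy in place of hydroxymethyl on a saturated chain carbon bound to an aromatic carbon. Among the compounds with values here, the step that bears most directly on this is the one from compound 2 to compound 3, which also altered the saturated chain on the same aromatic carbon and stayed within the scatter. None of the three measured steps moves this assay beyond the scatter, so no step beyond the scatter is expected here either; the expected step is a number 0.5 percentage points lower from compound 3 to compound 4 (within the scatter). For compound 4 the estimated value in this assay is 8%, with a range from 0% to 18%.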

Compound 4, a percentage reported as inhibition, at one concentration (the size of the read-out at that concentration, not a potency): 3.23%
For compound 4 the middle estimate is 4.8 percentage points above the measured one, within the range that was stated.
By their numbers in this assay, from the lowest: compounds 1, 4, 3 and 2 (each within the scatter of the next).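

In this assay, shortening 2-hydroxyethyl to hydroxymethyl gives a number 5.2 percentage points lower from compound 3 to compound 4 (within the scatter), so a one-carbon change in this hydroxy-bearing chain is not separated from the scatter. The other two comparisons with hydroxymethyl are no clearer, with a number 7.3 percentage points lower from compound 2 to compound 4 (within the scatter) against the pentyl group and a number 1.2 percentage points higher from compound 1 to compound 4 (within the scatter) against the ethoxycarbonyl group, so the four groups now shown at this place on the triazolyl ring cannot be ranked. Nothing available explains any of these numbers.

As far as these compounds go, it remains open whether an amine, a carboxylic acid or a longer chain ending in hydroxy at this place would give a step beyond the scatter. From the compounds shown here alone, it also remains open whether these four compounds would stay this close at a concentration other than the one tested here.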